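A few compounds are considered here, and "the series" means these few. Any claim that something is new, unique, unknown or untested is made for them only; others in the source may bear on it.

Of the compounds shown here, two in this set have been measured in a functional assay on SK-BR-3 cells (Homo sapiens) for antiproliferative activity, read by MTT assay, with a stated time of 72 h; a lower number here means a stronger inhibitor, a higher number a weaker inhibitor. Compound 1 `CCN1CCN(c2cc(C)c3cc(NC(=O)c4ccc(F)cc4)ccc3n2)CC1` gives 19800 nM in this assay, the lower of the two numbers. Compound 2 `Cc1cc(N2CCCCC2)nc2ccc(NC(=O)c3ccc(Cl)c(Cl)c3)cc12` gives 42500 nM in this assay, a higher number than that of compound 1 and beyond the scatter, so compound 1 stands as the stronger of the two measured compounds. The unmeasured compound 3 `CCN1CCN(c2cc(C)c3cc(NC(=O)c4ccc(Cl)cc4)ccc3n2)CC1` differs from compound 1 in one place: chloro in place of fluoro on an aromatic carbon. Going by the values given here, no measured pair in the set shows this same change, so its effect cannot be read from a comparable step. In this assay the expected step is a 1.3-fold lower number from compound 1 to compound 3 (0.12 log units; within the scatter), judged to be modest and, if anything, toward a somewhat lower number, but not clearly beyond the scatter. Compound 3 is therefore estimated at 15000 nM in this assay, with a range of 7000 nM to 40000 nM.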

Compound 3, half-maximal inhibitory concentration: 3020 nM
Compound 3: middle estimate off by 5.0-fold (0.70 log units), on the high side; measured number outside the range, below it.
By their numbers in this assay, from the lowest: compound 3; then compound 1; then compound 2.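

In this assay, the exchange of 4-fluorophenyl for 4-chlorophenyl on the carbonyl gives a 6.6-fold lower number from compound 1 to compound 3 (0.82 log units; beyond the scatter), so this aromatic carbon, para to a large group, is sensitive to the identity of its substituent. Until now, no comparable pair had shown what a change at this position does, and this single exchange of chloro for fluoro, with the rest of the structure unchanged, moves the number beyond the scatter. The data shown give no measured property that accounts for this step.

As far as these compounds go, it remains open whether bromo, methoxy or an amine at this same carbon would give a lower or a higher number than chloro. From the compounds shown here alone, it is also open whether the same exchange would produce a step of similar size on a compound carrying a piperidine in place of the ethylpiperazine.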